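This account rests on a few compounds, and the source may have more. Where it says the series, first, only, none or still open, it means among the compounds named here.

Compound 1 `C#CCOc1cccc(/C=C/C(=O)Nc2cc(C(=O)c3cc(OC)c(OC)c(OC)c3)ccc2OC)c1` and compound 2 `COc1ccc(C(=O)c2cc(OC)c(OC)c(OC)c2)cc1NC(=O)/C=C/c1ccc(F)cc1` share one core, and compound 3 `C#CCOc1cccc(/C=C/C(=O)Nc2cc(C(=O)c3cc(OC)c(OC)c(OC)c3)cc(OC)c2OC)c1` and compound 4 `COc1cc(C(=O)c2cc(OC)c(OC)c(OC)c2)cc(NC(=O)/C=C/c2ccc(F)cc2)c1OC` share another; the two cores differ by methoxy in place of hydrogen on an aromatic carbon. In a functional assay on PC-3 cells (Homo sapiens) for cytotoxicity, read by MTT assay, with a stated time of 72 h (on this read-out higher numbers stand for weaker inhibition and lower numbers for stronger inhibition), compound 1 gives 13100 nM, compound 2 gives 3200 nM and compound 3 gives 10100 nM. Between the two measured cores the step is a 1.3-fold lower number from compound 1 to compound 3 (0.11 log units; within the scatter), so the extra methoxy group on its own changes little.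

The change from compound 1 to compound 2 is 4-fluorophenyl in place of 3-(propargyloxy)phenyl on a double-bonded chain carbon bound to a double-bonded chain carbon, and it produced a 4.1-fold lower number from compound 1 to compound 2 (0.61 log units; beyond the scatter). Compound 4 differs from compound 3 by 4-fluorophenyl in place of 3-(propargyloxy)phenyl on a double-bonded chain carbon bound to a double-bonded chain carbon, the same change at the same place, now made on the core that carries the additional methoxy group. Among the compounds with values here, since the two cores sit close together in this assay, the one earlier example of this change is the main guide. The step from compound 3 to compound 4 is therefore expected to be about a 4.0-fold lower number from compound 3 to compound 4 (0.61 log units; beyond the scatter), similar in size to the earlier one, and compound 4 is estimated at 2500 nM, with a plausible range from 900 nM to 7000 nM.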

Compound 4, half-maximal inhibitory concentration: 4100 nM
The estimate for compound 4 lay 1.6-fold (0.21 log units) below the measured number, and the stated range covers the measured number.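

In this assay, putting 4-fluorophenyl in place of 3-(propargyloxy)phenyl on the core with the extra methoxy group gives a 2.5-fold lower number from compound 3 to compound 4 (0.39 log units; beyond the scatter) and so goes the same way as on the other core, by an amount that cannot be told apart from the earlier step: the same change on two cores in this assay, a 4.1-fold lower number (0.61 log units; beyond the scatter) from compound 1 to compound 2 and a 2.5-fold lower number (0.39 log units; beyond the scatter) from compound 3 to compound 4, 1.7-fold (0.22 log units) apart, within the scatter of two such steps. Seen from the other side, the extra methoxy group again changes little, with a 1.3-fold higher number from compound 2 to compound 4 (0.11 log units; within the scatter) matching its effect on the first pair: the same change on two cores in this assay, a 1.3-fold lower number (0.11 log units; within the scatter) from compound 1 to compound 3 and a 1.3-fold higher number (0.11 log units; within the scatter) from compound 2 to compound 4, 1.7-fold (0.22 log units) apart, within the scatter of two such steps. The change therefore carried over between these two closely related cores, but a single pair of cores does not show that it would carry to a more different core, and these numbers do not explain why the step occurs.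

The compounds shown leave open whether the same step would appear if the fluorine on the phenyl ring were replaced by an amine or a carboxylic acid. They also do not tell what a longer chain in place of the ethenyl link would do.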